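A few compounds are considered here, and "the series" means these few. Any claim that something is new, unique, unknown or untested is made for them only; others in the source may bear on it.

In a functional assay on EBC-1 cells (Homo sapiens) for inhibition, read by sulforhodamine B assay, with a stated time of 72 h (a lower number here means a stronger inhibitor, a higher number a weaker inhibitor), compound 3 `COc1ccc2c(OCCn3c(=O)oc4ccc(C)cc43)ccnc2c1` gives > 500 nM, which is a limit and not a number. Compound 1 `COc1ccc2c(OCCn3c(=O)oc4cc(C)ccc43)ccnc2c1` gives > 500 nM, also a limit. Compound 2 `Cc1ccc2c(c1)oc(=O)n2CCOc1ccnc2cc(OCCCN3CCCC3)ccc12` gives > 500 nM, again a limit. Among the measured compounds shown here, the whole series so far thus rests on (the limit of > 500 nM in this assay, at which 3 of the 3 values shown sit).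

Compound 4 `COc1ccc2c(OCCn3c(=O)oc4ccc(F)cc43)ccnc2c1` differs from compound 3 by fluoro in place of methyl on an aromatic carbon. For the measured compounds named here, no measured step covers this change. Going by the values given here, the one measured step, a step that the two limits leave unreadable from compound 1 to compound 2, sits elsewhere on the molecule and has no readable size. It therefore offers no guide to size or direction in this assay. With compound 3 at > 500 nM, compound 4 is expected to remain weak and most likely to be reported as a limit too. The estimated step that the limit leaves unreadable from compound 3 to compound 4 is expected to have no readable direction. For compound 4 the expected value is 800 nM, with an estimated range from 300 nM to 3000 nM.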

Compound 4, half-maximal inhibitory concentration: > 500 nM
Compound 4: a limit, no number; the forecaster's own chance of this, stated with the estimate: 85%; the middle value is on the limit's open side.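

No step from compound 3 to compound 4 can be read, as both results in this assay are limits and not numbers: the limit of > 500 nM in this assay, at which 4 of the 4 values shown sit.

The compounds shown leave open whether fluoro and methyl at this place differ at all in this assay, and which change to the shared core would give a measurable value.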